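The compounds below may be only part of what the source reports. "The series", "measured", "known", "first", "only" and "open" are said of these compounds alone.

In a functional assay on BT-474 cells (Homo sapiens) for inhibition, read by MTT assay, with a stated time of 5 days (on this read-out lower numbers stand for stronger inhibition and higher numbers for weaker inhibition), compound 1 `Cc1cc(Nc2nc(NCc3ccccc3Cl)nc3[nH]ncc23)n[nH]1` gives 7160 nM and compound 2 `Cc1cc(Nc2nc(NCc3cccc(Cl)c3)nc3[nH]ncc23)n[nH]1` gives 12900 nM. For the measured compounds named here, these two numbers lie within the usual scatter of each other, so compound 2 stands level with the only other measured compound. Compound 3 `Cc1cc(Nc2nc(NCc3ccc(F)cc3)nc3[nH]ncc23)n[nH]1` has not yet been measured in this assay. It carries 4-fluorophenyl in place of 3-chlorophenyl on a saturated chain carbon bound to a nitrogen on an aromatic ring. Going by the values given here, only one measured step bears on this change: 3-chlorophenyl in place of 2-chlorophenyl at the same place gave a 1.8-fold higher number from compound 1 to compound 2 (0.26 log units; within the scatter). Among the compounds with values here, that is thin evidence, as no compound with 4-fluorophenyl has been measured yet. Even so, no shift beyond the scatter is expected, and the estimated step is a 1.4-fold lower number from compound 2 to compound 3 (0.16 log units; within the scatter). Compound 3 is expected to give about 9000 nM, with an estimated range of 3500 nM to 23000 nM.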

Compound 3, half-maximal inhibitory concentration: 8750 nM
Estimate against measurement, compound 3: 1.0-fold (0.01 log units) above; measured number inside the range.
By their numbers in this assay, from the lowest: compounds 1, 3 and 2 (each within the scatter of the next).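

For the compounds shown here, putting 4-fluorophenyl in place of 3-chlorophenyl in this assay brings a 1.5-fold lower number from compound 2 to compound 3 (0.17 log units; within the scatter) and putting it in place of 2-chlorophenyl brings a 1.2-fold higher number from compound 1 to compound 3 (0.09 log units; within the scatter) and these are the first steps here that change the halogen itself, not only the ring position that carries it. All three compounds now stand level, so on a saturated chain carbon bound to a nitrogen on an aromatic ring, these three groups cannot be told apart in this assay. Nothing available explains why these groups stand level.

Going by these compounds, all three groups are halogen-bearing phenyl rings, so it stays open whether a plain phenyl, a phenyl carrying an amine or a carboxylic acid, or a longer chain leading to the ring would shift the number beyond the scatter. Changes elsewhere on the shared core also remain open.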